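Cytotoxicity of a naphthalenylmethyl analogue on keratinocytes

The source may report more compounds than this note shows. Statements on the series, on what has been measured and on what is new or still open speak of the compounds shown alone.

Measured compounds:
compound 1 `Cc1cccc(CSc2cc(Cl)c(C)cc2S(=O)(=O)/N=C(\N)N/N=C/C#Cc2ccccc2)c1` — 9000 nM
compound 2 `Cc1cc(S(=O)(=O)/N=C(\N)N/N=C/C#Cc2ccccc2)c(SCc2ccccc2C(F)(F)F)cc1Cl` — 23000 nM
compound 3 `C/C(C#Cc1ccccc1)=N\N/C(N)=N/S(=O)(=O)c1cc(C)c(Cl)cc1SCc1ccccc1C(F)(F)F` — 18000 nM

Of the compounds shown here, three sharing one sulfonyl core have been measured in an ADME assay on HaCaT cells (Homo sapiens) for cytotoxicity, read by MTT assay, with a stated time of 72 h; on this read-out higher numbers stand for weaker inhibition and lower numbers for stronger inhibition. Compound 2 gives the highest of the three numbers; compound 3 sits closest to it, with a 1.3-fold lower number from compound 2 to compound 3 (0.11 log units; within the scatter), while compound 1 lies furthest away, since a 2.6-fold higher number from compound 1 to compound 2 (0.41 log units; beyond the scatter).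

Compound 4 `Cc1cc(S(=O)(=O)/N=C(\N)N/N=C/C#Cc2ccccc2)c(SCc2cccc3ccccc23)cc1Cl` has not been measured. It differs from compound 2 by naphthalen-1-yl in place of 2-(trifluoromethyl)phenyl on a saturated chain carbon bound to a sulfur. For the measured compounds named here, only one measured step touches the same place: the change from compound 1 to compound 2, also a swap of one aromatic ring on the saturated chain carbon bound to a sulfur, moved the number modestly, by a 2.6-fold higher number from compound 1 to compound 2 (0.41 log units; beyond the scatter). The step from compound 2 to compound 3 concerns a different part of the molecule and stayed within the scatter, so it says little here. A step of similar modest size, in either direction, is therefore expected for compound 4 in this assay, written as a 1.4-fold lower number from compound 2 to compound 4 (0.16 log units; within the scatter). Compound 4 is estimated at 16000 nM, with a range from 6000 nM to 45000 nM.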

Compound 4, half-maximal inhibitory concentration: 5000 nM
Compound 4: the middle estimate sits 3.2-fold (0.51 log units) above what was measured, and the stated range ends above it.
By their numbers in this assay, from the lowest: compounds 4, 1, 3 and 2 (each within the scatter of the next, the first and the last beyond it).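

In this assay, for the compounds shown here, this second swap at the saturated chain carbon bound to a sulfur gives a 4.6-fold lower number from compound 2 to compound 4 (0.66 log units; beyond the scatter) and so, unlike the earlier compounds, shows a change at this place that lowers the number. Set against the other aromatic group, the change from 3-methylphenyl to naphthalen-1-yl gives a 1.8-fold lower number from compound 1 to compound 4 (0.26 log units; within the scatter) and stays inside the scatter, so the second six-membered aromatic ring does not separate these two compounds. Of the three groups compared here, 2-(trifluoromethyl)phenyl alone stands apart, with compound 2 beyond the scatter of both others, and nothing shown explains this difference.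

The compounds shown leave open whether naphthalen-2-yl, a cyclohexyl group or a group bearing a carboxylic acid would behave like naphthalen-1-yl at this place. They also leave open how the other change, seen from compound 2 to compound 3, would read with naphthalen-1-yl in place.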